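This account rests on a few compounds, and the source may have more. Where it says the series, first, only, none or still open, it means among the compounds named here.

In a physicochemical assay for solubility, read by chemiluminescence (a higher number here means a more soluble compound, a lower number a less soluble compound), compound 2 `O=C(CN(C(=O)c1ccc(-n2ccnc2)cc1)C1CCCCC1)Nc1cc(F)cc(F)c1` stands at the low end of the two measured compounds at 32 ug/mL and compound 1 `O=C(CN(C(=O)C1CCOCC1)C1CCCCC1)Nc1cc(F)cc(F)c1` gives 127 ug/mL with the gap between them beyond the usual scatter. Compound 3 `O=C(CN(C(=O)c1ccc(N2CCCC2)cc1)C1CCCCC1)Nc1cc(F)cc(F)c1` has pyrrolidin-1-yl in place of 1H-imidazol-1-yl on an aromatic carbon, para to a large group (pyrrolidin-1-yl in place of 1H-imidazol-1-yl on an aromatic carbon). For the measured compounds named here, no measured pair shows this exchange, so the expectation is tentative. In this assay a modest fall just beyond the scatter is expected, with a 2.7-fold lower number from compound 2 to compound 3 (0.43 log units; beyond the scatter) as the estimated step. Compound 3 is estimated at 12 ug/mL with a range from 3 ug/mL to 40 ug/mL expected.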

Compound 3, solubility: 5 ug/mL
Beside the measured number, compound 3's estimate is 2.4-fold (0.38 log units) above it; measured number inside the range.
By their numbers in this assay, from the lowest: compound 3; then compound 2; then compound 1.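

In this assay, for the compounds shown here, the first readable step is a 6.4-fold lower number from compound 2 to compound 3 (0.81 log units; beyond the scatter), which shows that this place, on an aromatic carbon para to a large group, is sensitive to the group it carries. Pyrrolidin-1-yl and 1H-imidazol-1-yl both have 5 heavy atoms, so heavy-atom count alone does not set the number here. No measurement at hand accounts for the step. Still open, from the compounds shown here alone, is how a dimethylamino group or a carboxylic acid on that carbon would read, and whether the step holds when the rest of the compound changes.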